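Moving the furan attachment point on a pyrimidine amide

This account rests on a few compounds, and the source may have more. Where it says the series, first, only, none or still open, it means among the compounds named here.

Of the compounds shown here, three have been measured in an assay on L cells for inhibition of Protein-serine O-palmitoleoyltransferase porcupine (Mus musculus), read by reporter gene assay, with a stated time of 24 h; on this read-out lower numbers stand for an effect already at smaller amounts and higher numbers for an effect only at larger amounts of compound. Compound 1 `COc1ccccc1-n1nc(C(=O)NCC(=O)Nc2nc3ccccc3s2)c2ccccc2c1=O` gives 10000 nM. Compound 2 `O=C(CSc1nc2c(c(=O)n1-c1ccccc1)SCC2)Nc1ncc(-c2ccco2)cn1` gives 3.5 nM, which is the second highest of the three numbers. Compound 3 `O=C(CSc1nc2c(c(=O)n1-c1ccccc1)SCC2)Nc1ccc(-c2cccnc2)cc1` gives 0.45 nM, a lower number than compound 2 by a step beyond the scatter, while the gap from compound 2 up to compound 1 is far beyond it. Going by the values given here, no pair of measured compounds differs in a single place, so no measured step guides the next change.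

Compound 4 `O=C(CSc1nc2c(c(=O)n1-c1ccccc1)SCC2)Nc1ncc(-c2ccoc2)cn1` keeps the shared core of compound 2 and differs from it only in this way: furan-3-yl in place of furan-2-yl on an aromatic carbon. The same atoms are present, joined differently, with the furan ring now attached through its third position rather than its second.

Among the compounds with values here, with no measured precedent, the step from compound 2 to compound 4 is expected to be small, in either direction, and likely not beyond the scatter, so that compound 4 is estimated at 4.5 nM in this assay, within a range from 1.2 nM to 15 nM, meaning an expected step of a 1.3-fold higher number from compound 2 to compound 4 (0.11 log units; within the scatter).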

Compound 4, half-maximal effective concentration: 1.5 nM
For compound 4 the middle estimate is 3.0-fold (0.48 log units) above the measured one, and the stated range covers the measured number.
By their numbers in this assay, from the lowest: compound 3; then compound 4; then compound 2; then compound 1.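

In this assay, the way the furan ring is joined to the six-membered aromatic ring with 2 nitrogen proves to matter at this place, para to a large group: furan-3-yl in place of furan-2-yl gives a 2.3-fold lower number from compound 2 to compound 4 (0.37 log units; beyond the scatter), a modest step. Going by these compounds alone, this is the first pair that differs in one place, and since the two compounds have the same atoms, the step reflects the attachment point of the furan alone. Nothing measured here explains the step.

Going by these compounds, whether a thiophen-3-yl group or a morpholine at the same place would continue this step remains open. Also open, on these data alone, is whether furan-3-yl would give a step of the same direction of compound 3, which differs from compound 4 in more than one place.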